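Removing one methyl: expectation for compound 3

A few compounds are considered here, and "the series" means these few. Any claim that something is new, unique, unknown or untested is made for them only; others in the source may bear on it.

For the measured compounds named here, compound 1 `COc1ccc(C=C(C(=O)/C=C/c2cccc(OC)c2OC)C(=O)/C=C/c2cccc(OC)c2OC)cc1OC` stands at the top of the two numbers so far in a functional assay on CNE-2 cells (Homo sapiens) for antiproliferative activity, read by sulforhodamine B assay, with a stated time of 48 h (a lower number here means a stronger inhibitor, a higher number a weaker inhibitor), where compound 1 gives 280 nM, though its gap to compound 2 is within the scatter. Compound 2 `COc1cc(C=C(C(=O)/C=C/c2cccc(OC)c2OC)C(=O)/C=C/c2cccc(OC)c2OC)cc(Br)c1O` gives in this assay 220 nM, the change being a 1.3-fold lower number from compound 1 to compound 2 (0.10 log units; within the scatter). Compound 3 `COc1ccc(C=C(C(=O)/C=C/c2cccc(OC)c2OC)C(=O)/C=C/c2cccc(OC)c2OC)cc1O` differs from compound 1 by hydrogen in place of methyl on an oxygen on an aromatic ring. Going by the values given here, the only measured step also alters the substituents on that aromatic ring and stays within the scatter, so a step no larger than the scatter is expected, a 1.1-fold lower number from compound 1 to compound 3 (0.03 log units; within the scatter). Compound 3 is therefore estimated at 260 nM, with a range from 120 nM to 560 nM.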

Compound 3, half-maximal inhibitory concentration: 220 nM
The estimate for compound 3 lay 1.2-fold (0.07 log units) above the measured number, within the range that was stated.
By their numbers in this assay, from the lowest: compounds 2, 3 and 1 (each within the scatter of the next).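

In this assay, replacing methoxy with hydroxy, which turns 3,4-dimethoxyphenyl into 3-hydroxy-4-methoxyphenyl, gives a 1.3-fold lower number from compound 1 to compound 3 (0.10 log units; within the scatter), so removing this one methyl leaves no readable change. Exchanging the 3-bromo-4-hydroxy-5-methoxyphenyl group for 3-hydroxy-4-methoxyphenyl gives no change at the digits printed from compound 2 to compound 3 (within the scatter), so the bromine and second methoxy group of compound 2 add no readable change here either. No evidence bears on this result. The compounds shown leave open whether an ethoxy group, a longer chain on that oxygen, or an amine or carboxylic acid in place of the hydroxy group would move the number beyond the scatter.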